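Cytotoxicity Limits Around a Shared Core

The source may hold more compounds than are shown below. What is called first, only, known or untested is meant among the compounds shown, and "the series" means these compounds.

Three compounds built on one core were tested in an ADME assay on HEL cells (Homo sapiens) for cytotoxicity, with a stated time of 3 days; a lower number here means that less compound is tolerated, a higher number that more compound is tolerated. Compound 1 `CCC1(Cc2ccccc2)OS(=O)(=O)C=C1OCc1ccccc1Cl` carries a 2-chlorophenyl on a saturated chain carbon bound to an oxygen on an unsaturated carbon. In this assay compound 1 gives only a limit of the assay, >= 20000 nM. Compound 2 `CCC1(Cc2ccccc2)OS(=O)(=O)C=C1OCC1CCCCC1` has cyclohexyl in that place. In this assay compound 2 likewise gives only a limit, >= 200000 nM. Compound 3 `CCC1(Cc2ccccc2)OS(=O)(=O)C=C1OCc1cccc(Cl)c1` carries 3-chlorophenyl there. In this assay compound 3 also stops at a limit, >= 20000 nM. Two of the values sit at the limit of >= 20000 nM in this assay, at which 2 of the 3 values shown sit, and one at the limit of >= 200000 nM in this assay, at which 1 of the 3 values shown sits. Every value is a limit, so the steps a step that the two limits leave unreadable from compound 1 to compound 2, a step that the two limits leave unreadable from compound 1 to compound 3 and a step that the two limits leave unreadable from compound 2 to compound 3 cannot be sized, and none of them shows whether the group in this place moves the read-out at all.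

Compound 4 `CCC1(Cc2ccccc2)OS(=O)(=O)C=C1OCc1ccc(C)cc1` differs from compound 3 by 4-methylphenyl in place of 3-chlorophenyl on a saturated chain carbon bound to an oxygen on an unsaturated carbon. Among the compounds with values here, no measured step bears directly on this change, and the steps that exist are unreadable. The step of a number no higher from compound 3 to compound 4 (the limit leaves the size open) is therefore expected to stay within the scatter. For compound 4 the expected value is 20000 nM, with a range from 10000 nM to 200000 nM, most probably again reported only as a limit.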

Compound 4, minimum cytotoxic concentration: >= 16000 nM
Compound 4: no number, only a limit (the forecaster's own chance of this, stated with the estimate: 85%); the middle value lies beyond the limit too.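

In this assay compound 4 also stops at a limit, >= 16000 nM. Since compound 1, compound 2 and compound 3 give only limits as well, none of the steps to compound 4 can be read. The compounds shown leave open whether the group in this place moves the minimum cytotoxic concentration at all, and where that concentration lies for any of them.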